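Amide aryl swap from compound 2 to compound 3

A few compounds are considered here, and "the series" means these few. Any claim that something is new, unique, unknown or untested is made for them only; others in the source may bear on it.

Measured so far in a functional assay on MCF7 cells (Homo sapiens) for antiproliferative activity, read by MTT assay, with a stated time of 24 h (on this read-out higher numbers stand for weaker inhibition and lower numbers for stronger inhibition), for this series
compound 1 `COC(=O)c1scc(-c2ccc(NC(=O)c3ccccn3)cc2)c1OC` gives 19200 nM
compound 2 `COC(=O)c1scc(-c2ccc(NC(=O)c3ccc(F)c(Cl)n3)cc2)c1OC` gives 10300 nM

Compound 2 at 10300 nM lies within the scatter of compound 1. The change 4-(trifluoromethyl)phenyl in place of 6-chloro-5-fluoropyridin-2-yl on a carbonyl carbon leads to compound 3 `COC(=O)c1scc(-c2ccc(NC(=O)c3ccc(C(F)(F)F)cc3)cc2)c1OC` which is not yet measured. Going by the values given here, at this same place the one measured step is a 1.9-fold lower number from compound 1 to compound 2 (0.27 log units; within the scatter) and it stayed within the scatter, so no shift beyond the scatter is expected in this assay in either direction. The expected step is a 1.2-fold higher number from compound 2 to compound 3 (0.07 log units; within the scatter) on this estimate. Compound 3 is estimated at 12000 nM with an expected range of 5000 nM to 30000 nM for now.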

Compound 3, half-maximal inhibitory concentration: 24600 nM
Estimate against measurement, compound 3: 2.1-fold (0.31 log units) below, within the range that was stated.
By their numbers in this assay, from the lowest: compounds 2, 1 and 3 (each within the scatter of the next, the first and the last beyond it).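

In this assay, going by these compounds alone, the swap gives a 2.4-fold higher number from compound 2 to compound 3 (0.38 log units; beyond the scatter) and is the first step at this place to pass the scatter, though a modest one. The other new step is a 1.3-fold higher number from compound 1 to compound 3 (0.11 log units; within the scatter) so 4-(trifluoromethyl)phenyl and pyridin-2-yl cannot be told apart here, and 6-chloro-5-fluoropyridin-2-yl stands apart from 4-(trifluoromethyl)phenyl alone. Nothing available bears on what lies behind this step. Still open, going by these compounds, is whether an amine, a carboxylic acid or a longer chain on this carbonyl carbon would move the number beyond the scatter in either direction.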